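Pyrrolidin-1-yl Against Piperidin-1-yl in a Weak Series

A few compounds are considered here, and "the series" means these few. Any claim that something is new, unique, unknown or untested is made for them only; others in the source may bear on it.

Compound 1 `CCn1c(/C=C2\SC(=O)N(CC(=O)N3CCCCC3)C2=O)nc2ccccc21` gives > 50000 nM in a functional assay on DU-145 cells (Homo sapiens) for inhibition, read by MTT assay, with a stated time of 48 h (on this read-out lower numbers stand for stronger inhibition and higher numbers for weaker inhibition), which is a limit of the assay and not a number.
Compound 2 `CCn1c(/C=C2\SC(=O)N(CC(=O)N3CCCC3)C2=O)nc2ccccc21` gives 45100 nM in this assay.
Compound 3 `CC(C)n1c(/C=C2\SC(=O)N(CC(=O)N3CCCC3)C2=O)nc2ccccc21` gives > 50000 nM in this assay, again a limit of the assay.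

All three measured compounds share one core, and all of them sit at or near the upper edge of what this assay can report. The change from compound 2 to compound 1 is piperidin-1-yl in place of pyrrolidin-1-yl on a carbonyl carbon, and it produces an at least 1.1-fold higher number from compound 2 to compound 1 (0.04 log units; that floor lies within the scatter); this step is bounded only because of the limit of > 50000 nM in this assay, at which 2 of the 3 values shown sit, so its true size is not known. The two cores differ by methyl in place of hydrogen on a saturated chain carbon bound to an aromatic nitrogen and a saturated chain carbon, which gives an at least 1.1-fold higher number from compound 2 to compound 3 (0.04 log units; that floor lies within the scatter), a step likewise cut off at the same limit.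

Compound 4 `CC(C)n1c(/C=C2\SC(=O)N(CC(=O)N3CCCCC3)C2=O)nc2ccccc21` has not yet been measured in this assay. It differs from compound 3 by piperidin-1-yl in place of pyrrolidin-1-yl on a carbonyl carbon, the same change that was made from compound 2 to compound 1, at a place described in the same words. Since compound 3 already stands at a limit, the expected step that the limit leaves unreadable from compound 3 to compound 4 can only be read as a floor, mirroring the earlier bounded step. Compound 4 is therefore expected to give about 80000 nM in this assay, most likely reported again as a limit, with the estimate spanning 40000 nM to 250000 nM.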

Compound 4, half-maximal inhibitory concentration: 42200 nM
Estimate against measurement, compound 4: 1.9-fold (0.28 log units) above; measured number inside the range.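

Piperidin-1-yl in place of pyrrolidin-1-yl on a carbonyl carbon gives an at least 1.1-fold lower number from compound 3 to compound 4 (0.07 log units; that floor lies within the scatter), and set beside the same change on the other core, this result can be read only as a floor: the same change on two cores in this assay, an at least 1.1-fold higher number (0.04 log units; that floor lies within the scatter) from compound 2 to compound 1 and an at least 1.1-fold lower number (0.07 log units; that floor lies within the scatter) from compound 3 to compound 4; the limit leaves it open whether they differ
The methyl change on the saturated chain carbon bound to the aromatic nitrogen reads the same way, with an at least 1.1-fold lower number from compound 1 to compound 4 (0.07 log units; that floor lies within the scatter), so that it too can be compared with its earlier counterpart only through floors: the same change on two cores in this assay, an at least 1.1-fold higher number (0.04 log units; that floor lies within the scatter) from compound 2 to compound 3 and an at least 1.1-fold lower number (0.07 log units; that floor lies within the scatter) from compound 1 to compound 4; the limit leaves it open whether they differ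
The four compounds therefore do not show that either change carries from one core to another with a fixed size or direction, and they do not show that it fails to carry, since every step among them has one end at the limit: the limit of > 50000 nM in this assay, at which 2 of the 4 values shown sit.

The compounds shown leave open whether another group on the carbonyl carbon, such as morpholin-4-yl or an open-chain diethylamino group, or a longer chain such as butyl on the aromatic nitrogen, would give a value well clear of the limit in this assay. They also leave open how the two changes behave on a core where both ends of each step can be read as numbers.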